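Cyclopropyl for ethyl on the aromatic nitrogen

The source may report more compounds than this note shows. Statements on the series, on what has been measured and on what is new or still open speak of the compounds shown alone.

In a functional assay on HeLa cells (Homo sapiens) for antiproliferative activity, read by MTT assay, with a stated time of 72 h (a higher number here means a weaker inhibitor, a lower number a stronger inhibitor), compound 3 (`CCn1cc(C(=O)O)c(=O)c2cc(F)c(N3CCN(C(=N)NS(=O)(=O)c4ccccc4Cl)CC3)cc21`) gives 32 nM. That is level with compound 1 (`N=C(NS(=O)(=O)c1ccccc1)N1CCN(c2cc3c(cc2F)c(=O)c(C(=O)O)cn3C2CC2)CC1`) at 32 nM and compound 2 (`Cc1ccc(S(=O)(=O)NC(=N)N2CCN(c3cc4c(cc3F)c(=O)c(C(=O)O)cn4C3CC3)CC2)cc1`) at 32 nM.

The unmeasured compound 4 (`N=C(NS(=O)(=O)c1ccccc1Cl)N1CCN(c2cc3c(cc2F)c(=O)c(C(=O)O)cn3C2CC2)CC1`) departs from compound 3 by a single exchange, cyclopropyl in place of ethyl on an aromatic nitrogen.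

Among the measured compounds shown here, no measured step covers this exchange directly. For the measured compounds named here, the only step measured at a single place is a methyl in place of hydrogen on an aromatic carbon, and it reads no change at the digits printed from compound 1 to compound 2 (within the scatter). It is a different change and bears on the present one only weakly. Compound 1 carries cyclopropyl and compound 3 carries ethyl, but the two differ in more than one place, so their equal values do not isolate the exchange.

Going by the values given here, since the only measured step, no change at the digits printed from compound 1 to compound 2 (within the scatter), stays within the scatter, no step beyond the scatter is expected in this assay, in either direction. The evidence is thin, and the range is kept wide for that reason. The expected step is no change at the digits printed from compound 3 to compound 4 (within the scatter).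

Compound 4 is estimated at 32 nM, with an expected range of 14 nM to 75 nM.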

Compound 4, half-maximal inhibitory concentration: 32 nM
The estimate for compound 4 equals the measured number at the digits printed; the range from low to high includes it.
By their numbers in this assay, from the lowest: compounds 1, 2, 3 and 4 (each within the scatter of the next).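

Cyclopropyl in place of ethyl on the aromatic nitrogen now has a direct reading in this assay, with no change at the digits printed from compound 3 to compound 4 (within the scatter) as the first step isolated at this position, so the larger group with its three-membered ring brings no step beyond the scatter here. With cyclopropyl held on the nitrogen, the aryl group on the sulfonyl sulfur also gains two readings: a chloro group added to the unsubstituted phenyl gives no change at the digits printed from compound 1 to compound 4 (within the scatter) and 2-chlorophenyl in place of 4-methylphenyl on a sulfonyl sulfur gives no change at the digits printed from compound 2 to compound 4 (within the scatter) as the measured outcome, so both exchanges on that aryl group stay within the scatter in this set. No measurement at hand accounts for these flat readings.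

On these data alone, the nitrogen exchange is read with the 2-chlorophenyl sulfonyl group only, so whether it holds with the unsubstituted phenyl or 4-methylphenyl partners stays open. Also open, as far as these compounds go, is whether a longer chain such as n-butyl, or a phenyl group, on the aromatic nitrogen, or an amine in place of the chloro group on the sulfonyl aryl group, would shift the reading in this assay.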